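A few compounds are considered here, and "the series" means these few. Any claim that something is new, unique, unknown or untested is made for them only; others in the source may bear on it.

Measured so far in a functional assay on the whole organism for inhibition, with Rattus norvegicus as the target; on this read-out lower numbers stand for an effect already at smaller amounts and higher numbers for an effect only at larger amounts of compound:
compound 1, `CCOC(=O)c1cnc2n(c1=O)C(C)CC/C2=N\Nc1cccc(C(=O)O)c1`: 100 umol/kg
compound 2, `CC1CC/C(=N\Nc2ccccc2)c2ncc(CC(=O)O)c(=O)n21`: 100 umol/kg
compound 3, `CC1CC/C(=N\Nc2ccc(Cl)cc2)c2ncc(C(=O)O)c(=O)n21`: 0.5 umol/kg

Among these three, compound 3 stands lowest on this assay. Compound 1 and compound 2 both sit far above it, and in each case the gap is beyond the scatter of repeated measurements, so compound 3 is the most potent of the measured set. Among the compounds with values here, no pair of measured compounds differs in only one place, so no single step can be read off from what has been measured.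

Compound 4, `CCCCc1ccc(N/N=C2\CCC(C)n3c2ncc(C(=O)O)c3=O)cc1`, has not yet been measured in this assay. It differs from compound 3 in one place: butyl in place of chloro on an aromatic carbon. The change is confined to the substituent on the aromatic carbon of the six-membered aromatic ring of carbon only, para to a large group; the rest of the molecule, including the carboxylic acid on the shared core, is unchanged.

Within the data shown here, since no measured pair shows what this kind of exchange does here, the expectation rests on compound 3 alone. The step from compound 3 to compound 4 is expected to be small and, if anything, toward a higher number: a 3.0-fold higher number from compound 3 to compound 4 (0.48 log units; beyond the scatter). Compound 4 is therefore expected to give about 1.5 umol/kg in this assay, within a range from 0.3 umol/kg to 8 umol/kg.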

Compound 4, dose for 50% inhibition: 7.8 umol/kg
Beside the measured number, compound 4's estimate is 5.2-fold (0.72 log units) below it; the measured number falls inside the stated range.
By their numbers in this assay, from the lowest: compound 3; then compound 4; then compounds 1 and 2 (each within the scatter of the next).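

In this assay, within the data shown here, the exchange of chloro for butyl on an aromatic carbon, para to a large group, gives a 16-fold higher number from compound 3 to compound 4 (1.19 log units; beyond the scatter), and this is the first step that can be read at a single place. It shows that this position is not indifferent to what it carries: with the carboxylic acid and the rest of the shared core unchanged, the substituent alone moves the dose needed for half-maximal inhibition well beyond the scatter, and the move is toward larger amounts of compound. The change brings in 4 heavy atoms in place of 1, while neither group has a hydrogen-bond donor, a hydrogen-bond acceptor or a net charge, so the step arises without any change in those counts. No evidence at hand explains why the step has this size or direction.

A single pair cannot show whether the number rises steadily with chain length, or whether it is chloro itself that favours the lower number. A shorter chain such as methyl, a bare hydrogen, or an oxygen-bearing group such as methoxy at this same carbon would leave that question open as well.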